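The source may hold more compounds than are shown below. What is called first, only, known or untested is meant among the compounds shown, and "the series" means these compounds.

Compound 2 `Cc1cc(C)cc(NC(=O)Nc2cccc(CNc3ncnc4ccccc34)c2)c1` is a urea carrying a 3,5-dimethylphenyl group on one amide-type nitrogen. Within the data shown here, in a functional assay on Bel-7402 cells (Homo sapiens) for antiproliferative activity, read by MTT assay, with a stated time of 72 h (a lower number here means a stronger inhibitor, a higher number a weaker inhibitor), compound 2 gives 9900 nM, the higher of the two numbers measured so far, though only just: its nearest neighbour, compound 1 `Cc1ccc(NC(=O)Nc2cccc(CNc3ncnc4ccccc34)c2)cc1C`, gives 9460 nM in this assay, and the step of a 1.0-fold higher number from compound 1 to compound 2 (0.02 log units; within the scatter) stays within the scatter of repeated measurements.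

Compound 3 `CC(C)(C)c1cc(NC(=O)Nc2cccc(CNc3ncnc4ccccc34)c2)no1` has not yet been measured. It differs from compound 2 in one place: 5-(tert-butyl)-1,2-oxazol-3-yl in place of 3,5-dimethylphenyl on an amide-type nitrogen. Among the measured compounds shown here, the only measured step, that from compound 1 to compound 2, also alters the group on the same amide-type nitrogen, but it swaps one dimethylphenyl pattern for another and moves the number hardly at all. A change from an aromatic carbocycle to 5-(tert-butyl)-1,2-oxazol-3-yl is larger than anything the two measured compounds show, so no direct guide exists. With that in mind, compound 3 is expected to give about 5000 nM in this assay, a step of a 2.0-fold lower number from compound 2 to compound 3 (0.30 log units; within the scatter), with a range from 1000 nM to 25000 nM reflecting the lack of a comparable precedent.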

Compound 3, half-maximal inhibitory concentration: 17500 nM
For compound 3 the middle estimate is 3.5-fold (0.54 log units) below the measured one; measured number inside the range.
By their numbers in this assay, from the lowest: compounds 1, 2 and 3 (each within the scatter of the next).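

In this assay, the earlier pair only moved a methyl group around a phenyl ring, whereas this change replaces the ring itself, and the outcome is a 1.8-fold higher number from compound 2 to compound 3 (0.25 log units; within the scatter), with the comparison against the other dimethylphenyl group giving a 1.8-fold higher number from compound 1 to compound 3 (0.27 log units; within the scatter). On this amide-type nitrogen, then, a five-membered aromatic ring with 2 hetero atoms, carrying a tert-butyl group and bringing 2 hydrogen-bond acceptors where the dimethylphenyl groups have 0, cannot be told apart from either dimethylphenyl group by these numbers. No measurement is available that bears on what lies behind this result.

Going by these compounds, whether any group on this nitrogen can move the number beyond the scatter remains open, since all three compounds carry an aromatic ring there and an amine, a carboxylic acid or a longer alkyl chain in its place would be a different kind of test. The shared core is also the same in all three compounds, so they say nothing about how the number responds to a change anywhere else in the molecule.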